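Trading 1,1-difluoroethyl for ethoxy

The compounds below may be only part of what the source reports. "The series", "measured", "known", "first", "only" and "open" are said of these compounds alone.

Within the data shown here, in a physicochemical assay for lipophilicity, at pH 7.4 (on this read-out higher numbers stand for higher lipophilicity and lower numbers for lower lipophilicity), compound 1 `COCCc1nc2nc(C)cc(Nc3ccc(S(F)(F)(F)(F)F)cc3)n2n1` gives 3, while compound 2 `Cc1cc(Nc2ccc(S(F)(F)(F)(F)F)cc2)n2nc(C(C)(F)F)nc2n1` gives 3.6, the higher of the two numbers so far. Compound 3 `CCOc1nc2nc(C)cc(Nc3ccc(S(F)(F)(F)(F)F)cc3)n2n1` has not yet been measured. Its structure departs from that of compound 2 at a single place, with ethoxy in place of 1,1-difluoroethyl on an aromatic carbon. Among the measured compounds shown here, only one measured step bears on this change, and it involves the same place and the same 1,1-difluoroethyl group: a number 0.60 log units higher from compound 1 to compound 2 (beyond the scatter). Here that group leaves rather than enters, so the number should fall, though one step is thin evidence and ethoxy is a different group from the one in compound 1. The expected step is a number 0.40 log units lower from compound 2 to compound 3 (beyond the scatter). Compound 3 is therefore estimated at 3.2, with an expected range from 2.8 to 3.6.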

Compound 3, distribution coefficient: 3.4
Compound 3: middle estimate off by 0.20 log units, on the low side, within the range that was stated.
By their numbers in this assay, from the lowest: compound 1; then compounds 3 and 2 (each within the scatter of the next).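

Replacing 1,1-difluoroethyl with ethoxy at this position gives a number 0.20 log units lower from compound 2 to compound 3 (within the scatter) in this assay and so, on this read-out, the two groups cannot be told apart on this core. Ethoxy in place of 2-methoxyethyl gives a number 0.40 log units higher from compound 1 to compound 3 (beyond the scatter) in this assay and so 2-methoxyethyl now differs from two other groups at this aromatic carbon, not only from 1,1-difluoroethyl. Nothing measured here explains why these groups compare as they do.

The compounds shown leave open whether other groups at this carbon, such as an amine, a carboxylic acid or a longer chain like butoxy, would fall close to ethoxy and 1,1-difluoroethyl or well away from them. They also leave open whether ethoxy and 1,1-difluoroethyl would still match in a different kind of measurement.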